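This account rests on a few compounds, and the source may have more. Where it says the series, first, only, none or still open, it means among the compounds named here.

Measured so far in a functional assay on A549 cells (Homo sapiens) for inhibition, read by CCK-8 assay, with a stated time of 72 h, tested at 10 uM; a higher number here means more inhibition of growth at the concentration tested, a lower number less inhibition of growth:
- compound 1, `CN(C)C(=O)c1cc2cnc(Nc3ccc(NC(=O)C4(C(=O)Nc5cccc(F)c5)CC4)cc3)nc2n1C1CCCC1`: 91.8%
- compound 2, `CN(C)C(=O)c1cc2cnc(Nc3ccc(NC(=O)C4(C(=O)Nc5ccc(Cl)c(C(F)(F)F)c5)CC4)cc3)nc2n1C1CCCC1`: 88.1%
- compound 3, `CN(C)C(=O)c1cc2cnc(Nc3ccc(NC(=O)C4(C(=O)Nc5cccc(C(F)(F)F)c5)CC4)cc3)nc2n1C1CCCC1`: 89.2%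

Compound 1 shows the largest number of the three, but the gaps are small: a number 3.7 percentage points lower from compound 1 to compound 2 (within the scatter) and a number 2.6 percentage points lower from compound 1 to compound 3 (within the scatter). Compound 4, `CN(C)C(=O)c1cc2cnc(Nc3ccc(NC(=O)C4(C(=O)Nc5ccccc5)CC4)cc3)nc2n1C1CCCC1`, differs from compound 1 only in this: hydrogen in place of fluoro on an aromatic carbon. Among the compounds with values here, two measured steps bear on it. Swapping the substituent at the same aromatic carbon gave a number 2.6 percentage points lower from compound 1 to compound 3 (within the scatter), and removing a halogen from the aromatic ring gave a number 1.1 percentage points higher from compound 2 to compound 3 (within the scatter); both sit within the scatter. Removal of the fluoro is therefore expected to produce no step beyond the scatter in this assay, and compound 4 is estimated at 90%, range 82% to 96%. The expected step is a number 1.8 percentage points lower from compound 1 to compound 4 (within the scatter).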

Compound 4, percent growth inhibition at one concentration: 88.8%
The estimate for compound 4 lay 1.2 percentage points above the measured number; measured number inside the range.
By their numbers in this assay, from the lowest: compounds 2, 4, 3 and 1 (each within the scatter of the next).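

In this assay, within the data shown here, the bare phenyl supplies the unsubstituted reference for this ring, which the earlier compounds lacked: the steps are a number 3 percentage points lower from compound 1 to compound 4 (within the scatter) and a number 0.4 percentage points lower from compound 3 to compound 4 (within the scatter) and a number 0.7 percentage points higher from compound 2 to compound 4 (within the scatter). Fluoro, trifluoromethyl and the 4-chloro-3-(trifluoromethyl)phenyl pattern therefore cannot be told apart from hydrogen here, so no substituent on this ring is needed to keep the number. Nothing available explains this flat result. Open, on these data alone, is whether an amine or a carboxylic acid on this ring would give a step beyond the scatter.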